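A few compounds are considered here, and "the series" means these few. Any claim that something is new, unique, unknown or untested is made for them only; others in the source may bear on it.

Measured compounds:
compound 1, `COc1ccc(-c2cc(/C=C/C(=O)c3ccc(N)cc3)[nH]n2)cc1`: -53%
compound 2, `COc1ccc(-c2cc(/C=C/C(=O)c3ccc(N)cc3)[nH]n2)cc1OC`: -73%
compound 3, `COc1cc(C(=O)/C=C/c2cc(-c3cc(OC)c(OC)c(OC)c3)n[nH]2)cc(OC)c1OC`: -99%

All three numbers come from a functional assay on HCT-116 cells (Homo sapiens) for cytotoxicity, read by sulforhodamine B assay, with a stated time of 48 h, tested at 10 uM; a lower number here means a stronger effect, a higher number a weaker effect of the compound at the concentration tested. Compound 3 stands lowest of the three; its nearest neighbour in value is compound 2, and compound 1 is furthest from it, both gaps beyond the scatter.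

One change is seen twice in the set. Between the measured pair it is hydrogen in place of methoxy on an aromatic carbon, and it gave a number 20 percentage points higher from compound 2 to compound 1 (beyond the scatter). The same kind of change leads from compound 3 to the not yet measured compound 4, `COc1ccc(-c2cc(/C=C/C(=O)c3cc(OC)c(OC)c(OC)c3)[nH]n2)cc1OC`: here it is hydrogen in place of methoxy on an aromatic carbon. The two places are not the same word for word: in compound 3 the carbon that loses the methoxy is also meta to a second methoxy group, whereas in compound 2 it is only ortho to a methoxy group and meta to a large group. How the core of compound 3 differs from that of compound 2 is not broken down here.

Given that the earlier instance of this change gave a number 20 percentage points higher from compound 2 to compound 1 (beyond the scatter), a step of about the same size is expected for compound 4, that is a number 19 percentage points higher from compound 3 to compound 4 (beyond the scatter). On this basis compound 4 is estimated at -80% in this assay. The range for compound 4 is estimated to run from -100% to -55%, the lower end reflecting that compound 3 already sits near the bottom of what this read-out reports.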

Compound 4, a percentage reported as activity, at one concentration (the size of the read-out at that concentration, not a potency): -81%
Compound 4: the middle estimate sits 1 percentage points above what was measured; measured number inside the range.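

Replacing methoxy with hydrogen on an aromatic carbon in this assay gave a number 18 percentage points higher from compound 3 to compound 4 (beyond the scatter). Set beside the earlier instance of the same change, the step carries from one core to the other with no difference beyond the scatter: the same change on two cores in this assay, a number 20 percentage points higher (beyond the scatter) from compound 2 to compound 1 and a number 18 percentage points higher (beyond the scatter) from compound 3 to compound 4, 2 percentage points apart, within the scatter of two such steps. Going by these compounds alone, this does not show that the step would hold on further cores or at other places on the ring, since it rests on only two pairs, read at a single concentration, and the carbon concerned in compound 3 is also meta to a second methoxy group, so the two places are not identical.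

Still open, on these data alone, is whether a different replacement at that carbon, such as hydroxy, fluorine or the longer ethoxy chain, would shift the number in this assay in the same direction and by a similar amount as hydrogen does. Also open, as far as these compounds go, is how the amine carried by compound 1 and compound 2 would fare against an amide or a carboxylic acid at the same place, and whether the methoxy step would then stay the same size.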